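Thiophen-2-yl for 4-chlorophenyl: expected binding of compound 3

A few compounds are considered here, and "the series" means these few. Any claim that something is new, unique, unknown or untested is made for them only; others in the source may bear on it.

compound 1 `CC(C)(C)Cc1c(-c2ccc(Cl)cc2)sc(N)c1C(=O)c1ccc(Cl)cc1` — 1%
compound 2 `COCCOc1ccc(-c2sc(N)c(C(=O)c3ccc(Cl)cc3)c2CC(C)(C)C)cc1` — 1%

In an assay on CHO cells for displacement of a labelled ligand from adenosine receptor A1 (Homo sapiens), read by scintillation counting, tested at 10 uM (a lower number here means less inhibition, a higher number more inhibition at the concentration tested (going by the name of the read-out)), compound 1 gives 1% and compound 2 gives 1%; compound 1 stands level with compound 2, the step of no change at the digits printed from compound 1 to compound 2 (within the scatter) lying within the scatter. Compound 3 `CC(C)(C)Cc1c(-c2cccs2)sc(N)c1C(=O)c1ccc(Cl)cc1` differs from compound 1 as thiophen-2-yl in place of 4-chlorophenyl on an aromatic carbon. Among the compounds with values here, no measured step exchanges the 4-chlorophenyl group; the one step in hand, no change at the digits printed from compound 1 to compound 2 (within the scatter), alters another group and stays within the scatter, so it bears only loosely on this change. Compound 3 is therefore expected to remain near the floor, with a number 2 percentage points higher from compound 1 to compound 3 (within the scatter) meaning no step beyond the scatter. The estimate for compound 3 is 3%, range 0% to 15%.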

Compound 3, a percentage reported as inhibition, at one concentration (the size of the read-out at that concentration, not a potency): 1%
Compound 3: middle estimate off by 2 percentage points, on the high side; measured number inside the range.
By their numbers in this assay, from the lowest: compounds 1, 2 and 3 (each within the scatter of the next).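

In this assay, the exchange of the whole 4-chlorophenyl ring for thiophen-2-yl gives no change at the digits printed from compound 1 to compound 3 (within the scatter), so this position, next to the ring sulfur, now has a direct exchange of that ring on record. A five-membered ring with sulfur and no chlorine reads the same here as the six-membered carbon ring, and neither ring lifts the number off the low end. No measurement in hand bears on this result.

Going by these compounds, whether a piperidine or a carboxylic acid at this position would move the number in this assay stays open. So does the effect of replacing the neopentyl group with a shorter chain such as ethyl.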